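Chloro in place of nitro: expected cytotoxicity step

A few compounds are considered here, and "the series" means these few. Any claim that something is new, unique, unknown or untested is made for them only; others in the source may bear on it.

Measured so far in an ADME assay on HEK-293T cells (Homo sapiens) for cytotoxicity, read by CCK-8 assay, with a stated time of 48 h; a higher number here means a weaker inhibitor, a lower number a stronger inhibitor:
- compound 1 `Nc1ccc(Oc2ccccc2-c2ccc(S(=O)(=O)NCCNC(=O)Nc3ccc(Cl)cc3)s2)cc1` gives > 20000 nM as a limit
- compound 2 `O=C(NCCNS(=O)(=O)c1ccc(-c2ccccc2Oc2ccc([N+](=O)[O-])c([N+](=O)[O-])c2)s1)Nc1ccc([N+](=O)[O-])cc1` gives 16600 nM as a number

Compound 1 stands at the limit of > 20000 nM in this assay, at which 1 of the 2 values shown sits, and that is a limit, not a number. Among the compounds with values here, compound 2 with 16600 nM is the only number in hand, so the two cannot be ranked.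

The next compound is compound 3 `O=C(NCCNS(=O)(=O)c1ccc(-c2ccccc2Oc2ccc([N+](=O)[O-])c([N+](=O)[O-])c2)s1)Nc1ccc(Cl)cc1` and it differs from compound 2 in one place. The change is chloro in place of nitro on an aromatic carbon with chloro in place of nitro on an aromatic carbon, para to a large group.

No measured step sizes this change, so no step beyond the scatter is expected in this assay and a limit result remains possible. The estimated move a 1.1-fold higher number from compound 2 to compound 3 (0.04 log units; within the scatter) is expected to stay within that scatter. For compound 3 the estimate is 18000 nM with an expected range of 8000 nM to 40000 nM for now.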

Compound 3, half-maximal inhibitory concentration: > 20000 nM
Compound 3 gave a limit, no number (the forecaster's own chance of this, stated with the estimate: 40%); middle value at least 1.1-fold (0.04 log units) from the limit.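

In this assay compound 3 gives > 20000 nM, which is a limit and not a number. Within the data shown here, the change from 4-nitrophenyl to 4-chlorophenyl provides the first step at this position, an at least 1.2-fold higher number from compound 2 to compound 3 (0.08 log units; that floor lies within the scatter), so chloro in place of nitro has only a floor on its size and shows no move beyond the scatter. The step between compound 1 and compound 3 cannot be read, and compound 3 now shares the limit with compound 1: the limit of > 20000 nM in this assay, at which 2 of the 3 values shown sit.

Among these compounds, compound 2 at 16600 nM remains the only number, so the true size of this change in this assay stays open. Also open, from the compounds shown here alone, is whether an amine or a carboxylic acid on the same aromatic carbon would give a number rather than a limit.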